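A few compounds are considered here, and "the series" means these few. Any claim that something is new, unique, unknown or untested is made for them only; others in the source may bear on it.

In a functional assay on SW982 cells (Homo sapiens) for inhibition, read by MTT assay, with a stated time of 72 h (a lower number here means a stronger inhibitor, a higher number a weaker inhibitor), compound 1 `COc1cc(OC)c(OC)cc1/C=C/C(=O)c1ccc(O)cc1O` gives 32400 nM, and compound 2 `COc1cc(OC)c(OC)cc1/C=C/C(=O)c1ccc(F)cc1` gives 32500 nM. Among the compounds with values here, these are the only two numbers available, and they cannot be told apart: a 1.0-fold higher number from compound 1 to compound 2 (0.00 log units; within the scatter). Compound 2 therefore stands level with compound 1 and has no separation from it.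

The next structure is compound 3 `COc1cc(OC)c(OC)cc1/C=C/C(=O)c1cc(O)ccc1O`, which keeps the shared core of compound 2 but carries a different group on a carbonyl carbon: 2,5-dihydroxyphenyl in place of 4-fluorophenyl on a carbonyl carbon. This places 2,5-dihydroxyphenyl in place of 4-fluorophenyl.

Within the data shown here, only one measured step bears on this change, the exchange between 2,4-dihydroxyphenyl and 4-fluorophenyl at the same place, and it stayed within the scatter. Among the measured compounds shown here, no compound with 2,5-dihydroxyphenyl has yet been measured, so this single comparison is thin support. Even so, compound 1 at 32400 nM gives no reason to expect a sizeable step in this assay in either direction.

The expected step is a 1.1-fold lower number from compound 2 to compound 3 (0.03 log units; within the scatter), which is no change beyond the scatter. For compound 3 the estimated value is 30000 nM, with an expected range from 12000 nM to 60000 nM.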

Compound 3, half-maximal inhibitory concentration: > 150000 nM
Compound 3 ended at the assay's limit; the forecaster's own chance of this, stated with the estimate: 10%; middle value at least 5.0-fold (0.69 log units) away from the limit.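

Compound 3 gives > 150000 nM in this assay, and this is a limit of the assay, not a number. The place on the carbonyl carbon, which had shown no separation when 2,4-dihydroxyphenyl and 4-fluorophenyl were exchanged, does respond to the entry of 2,5-dihydroxyphenyl: the change gives an at least 4.6-fold higher number from compound 2 to compound 3 (0.66 log units; beyond the scatter), and measured against the other dihydroxyphenyl group it gives an at least 4.6-fold higher number from compound 1 to compound 3 (0.66 log units; beyond the scatter). The flat first step therefore did not mean that any group is accepted at this place, since 2,5-dihydroxyphenyl and 2,4-dihydroxyphenyl, which differ in one place only, part beyond the scatter.

Going by these compounds, how far these steps really reach stays open, because the result for compound 3 is bounded on one side only: the limit of > 150000 nM in this assay, at which 1 of the 3 values shown sits. Also open is what a phenyl ring carrying a single hydroxyl, an amine or a carboxylic acid would do on this carbonyl carbon, and so whether the loss belongs to 2,5-dihydroxyphenyl alone or extends to other groups at this place.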